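Phenoxy for trifluoromethylphenyl in a sulfonylacetic acid series

The compounds below may be only part of what the source reports. "The series", "measured", "known", "first", "only" and "open" are said of these compounds alone.

Measured compounds:
- compound 1, `O=C(O)CS(=O)(=O)c1ccc(OCc2cccc(-c3ccccc3C(F)(F)F)c2)cc1`: 52.5 nM
- compound 2, `Cc1nc(-c2ccccc2F)sc1COc1ccc(S(=O)(=O)CC(=O)O)cc1`: 550 nM
- compound 3, `Cc1cccc(-c2nc(C)c(COc3ccc(S(=O)(=O)CC(=O)O)cc3)s2)c1`: 214 nM

In a functional assay on CHO cells for agonist activity at Free fatty acid receptor 1 (Homo sapiens), read by FLIPR and calcium flux (on this read-out lower numbers stand for an effect already at smaller amounts and higher numbers for an effect only at larger amounts of compound), compound 1 gives the lowest number of the three. Compound 3 comes nearest, and compound 2 stands furthest away; both gaps lie beyond the scatter. Going by the values given here, the only step between measured compounds, a 2.6-fold lower number from compound 2 to compound 3 (0.41 log units; beyond the scatter), concerns the aryl group on the shared core of compounds 2 and 3 and not the part that changes here.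

Compound 4, `O=C(O)CS(=O)(=O)c1ccc(OCc2cccc(Oc3ccccc3)c2)cc1`, differs from compound 1 by phenoxy in place of 2-(trifluoromethyl)phenyl on an aromatic carbon, a group on an aromatic carbon, meta to a large group. Among the compounds with values here, no measured step speaks to this exchange, so the expectation rests on compound 1 alone and carries a wide range. A modest rise in the number is expected, a 2.9-fold higher number from compound 1 to compound 4 (0.46 log units; beyond the scatter), since the only directly comparable core is that of compound 1, which gives 52.5 nM. For compound 4 in this assay the estimate is 150 nM, within 40 nM to 600 nM.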

Compound 4, half-maximal effective concentration: 97.7 nM
Estimate against measurement, compound 4: 1.5-fold (0.19 log units) above; measured number inside the range.
By their numbers in this assay, from the lowest: compounds 1 and 4 (each within the scatter of the next); then compound 3; then compound 2.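

In this assay, replacing 2-(trifluoromethyl)phenyl with phenoxy gives a 1.9-fold higher number from compound 1 to compound 4 (0.27 log units; within the scatter), so this read-out does not separate the two compounds. The position on the aromatic carbon, meta to a large group, therefore holds either an aryl group carrying trifluoromethyl or a phenoxy group with its added hydrogen-bond acceptor, and the number stays within the scatter for this one pair. Nothing measured here accounts for this outcome.

From the compounds shown here alone, how a plain phenyl, a benzyl or a methoxy group would read at this same place remains open, so the part played by the oxygen link in compound 4 cannot be separated from that of the ring it carries. Also open, going by these compounds, is whether a fluorine or a methyl on the phenoxy ring would shift the number beyond the scatter.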